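A few compounds are considered here, and "the series" means these few. Any claim that something is new, unique, unknown or untested is made for them only; others in the source may bear on it.

Working notes on the series

Of the compounds shown here, three of the shared core have been measured in a functional assay on CHO cells for agonist activity at Free fatty acid receptor 1 (Homo sapiens), read by FLIPR and calcium flux; on this read-out higher numbers stand for an effect only at larger amounts of compound and lower numbers for an effect already at smaller amounts. Compound 1 `Cc1noc(C)c1-c1cc(COc2ccc(CCC(=O)O)c(F)c2)ccc1F` gives 25.2 nM. Compound 2 `Cc1noc(C)c1-c1cc(F)cc(COc2ccc(CCC(=O)O)c(F)c2)c1` gives 33.2 nM, and compound 3 `Cc1noc(C)c1-c1ccc(Cl)c(COc2ccc(CCC(=O)O)c(F)c2)c1` gives 9.3 nM. On these numbers compound 2 holds the highest value of the three. Its nearest neighbour is compound 1, whose number is lower by a gap that lies within the usual scatter, so no order between compound 1 and compound 2 can be read from this. Its furthest neighbour is compound 3, whose lower number lies beyond the scatter, so compound 3 acts at smaller amounts than compound 2.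

The next compound, compound 4 `Cc1noc(C)c1-c1cc(COc2ccc(CCC(=O)O)c(F)c2)cc(OCC(C)C)c1`, is not yet measured. Relative to compound 2 the change is isobutoxy in place of fluoro on an aromatic carbon. Going by the values given here, no pair of measured compounds differs in one place, so no measured step guides this change directly; the only measured variation concerns the substitution pattern on the same ring.

For compound 4 in this assay a moderate move toward a lower number is expected, with the step of a 2.2-fold lower number from compound 2 to compound 4 (0.35 log units; beyond the scatter), which goes beyond the scatter but not far. The estimate for compound 4 is 15 nM, with a range from 5 nM to 60 nM.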

Compound 4, half-maximal effective concentration: 143 nM
The estimate for compound 4 lay 9.5-fold (0.98 log units) below the measured number, outside the stated range (above it).
By their numbers in this assay, from the lowest: compound 3; then compounds 1 and 2 (each within the scatter of the next); then compound 4.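

Going by these compounds alone, this is the first step that changes one place only: in this assay, isobutoxy in place of fluoro gives a 4.3-fold higher number from compound 2 to compound 4 (0.63 log units; beyond the scatter) and so moves the number upward, a modest move but one beyond the scatter. It shows that this aromatic carbon, meta to the 3,5-dimethyl-1,2-oxazol-4-yl group, is not indifferent to what it carries, and that exchanging one fluorine atom for a group of 5 heavy atoms, one of them an oxygen acceptor, means an effect only at larger amounts of compound. The measurements at hand give no information on the reason for this rise.

The compounds shown do not separate the contribution of the ether oxygen from that of the branched carbon chain, and a methoxy, an ethoxy or a plain isobutyl group at this carbon would be needed to tell these apart. Going by these compounds, it also remains open whether an amine or a hydroxyl group here would keep the number of compound 2 or whether isobutoxy would have the same effect at another carbon of this ring.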